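This account rests on a few compounds, and the source may have more. Where it says the series, first, only, none or still open, it means among the compounds named here.

Measured so far in an ADME assay on HepG2 cells (Homo sapiens) for cytotoxicity, read by CellTiter-Glo, with a stated time of 48 h; a lower number here means that less compound is tolerated, a higher number that more compound is tolerated:

Compound 1 `O=C(CCCOc1ccccc1)Nc1ncc(Br)s1`: 1600 nM
Compound 2 `Cc1cnc(NC(=O)CCCOc2cncc(Cl)c2)s1`: 1700 nM
Compound 3 `Cc1cc(OCCCC(=O)Nc2ncc(Cl)s2)ccc1Cl`: 4400 nM

Since a higher number here means that more compound is tolerated, the low end of this small set is where cells are affected at the smallest dose. Compound 1, at 1600 nM, shares that low end with compound 2, at 1700 nM, as the two lie within the usual scatter of each other. Compound 3, at 4400 nM, stands beyond the scatter above compound 1.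

The next compound to be tested is compound 4 `Cc1cnc(NC(=O)CCCOc2ccccc2)s1`. Its change from compound 1 is a single swap: methyl in place of bromo on an aromatic carbon. In short, it has methyl in place of bromo on an aromatic carbon, turning 5-bromo-1,3-thiazol-2-yl into 5-methyl-1,3-thiazol-2-yl.

Among the measured compounds shown here, no measured pair differs in one place only, so the size of this swap cannot be read directly from the data. Compound 2 also carries a methyl at that place and gives 1700 nM, though it differs elsewhere as well. Only a small rise in this assay is therefore expected, with no clear move beyond the scatter. The estimated change is a 1.6-fold higher number from compound 1 to compound 4 (0.19 log units; within the scatter). For compound 4 the expected value is 2500 nM, with an estimated range from 1000 nM to 7000 nM.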

Compound 4, half-maximal cytotoxic concentration: 9000 nM
For compound 4 the middle estimate is 3.6-fold (0.56 log units) below the measured one; the whole stated range lies below it.
By their numbers in this assay, from the lowest: compounds 1 and 2 (each within the scatter of the next); then compound 3; then compound 4.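

Among the compounds shown here, this is the first pair in the set that differs in one place only, so the size of a change at this carbon next to the ring sulfur can now be read. In this assay, going from 5-bromo-1,3-thiazol-2-yl to 5-methyl-1,3-thiazol-2-yl gives a 5.6-fold higher number from compound 1 to compound 4 (0.75 log units; beyond the scatter), which shows that this one position can move the amount of compound the cells tolerate, even though only one heavy atom is exchanged and no ring, hydrogen-bond donor, hydrogen-bond acceptor or net charge enters or leaves. Nothing available here explains why the methyl compound is tolerated at a higher concentration than the bromo compound.

A single pair cannot tell whether the step comes from gaining the methyl or from losing the bromo, nor whether the same swap would give a step of similar size with a different group on the other side of the amide. Going by these compounds, how a bare hydrogen, an amine or a longer chain on this carbon would behave also remains open.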